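This account rests on a few compounds, and the source may have more. Where it says the series, first, only, none or still open, it means among the compounds named here.

Compound 1, `CC(C)[C@H](NC(=O)CN(c1nc(Cl)nc2[nH]cnc12)C1CC1)C(=O)OCc1ccccc1`: 17.9%
Compound 2, `CSCC[C@H](NC(=O)CN(c1nc(Cl)nc2[nH]cnc12)C1CC1)C(=O)OCc1ccccc1`: 17.6%
Compound 3, `CSCC[C@H](NC(=O)CN(c1ncnc2c1ncn2C1CCCCO1)C1CC1)C(=O)OCc1ccccc1`: 17.5%

These three compounds were tested in a functional assay on the whole organism (Tail, strain ICR) with Mus musculus as the target, in the tail flick test, with a stated time of 150 min, at a dose of 25 umol/kg by the oral route; a higher number here means a stronger effect of the compound at the dose given, a lower number a weaker effect. In this assay compound 1 gives 17.9%, compound 2 gives 17.6% and compound 3 gives 17.5%. All three numbers lie within the usual scatter of one another, so nothing separates them here.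

Compound 1 and compound 2 share a core and differ in one place: isopropyl in place of 2-(methylsulfanyl)ethyl on a saturated chain carbon bound to an amide-type nitrogen and a carbonyl carbon. The step that this change made is a number 0.3 percentage points higher from compound 2 to compound 1 (within the scatter). Compound 3 carries a different core; the difference between the cores of compound 2 and compound 3 is not broken down here.

Compound 4, `CC(C)[C@H](NC(=O)CN(c1ncnc2c1ncn2C1CCCCO1)C1CC1)C(=O)OCc1ccccc1`, has not yet been measured in this assay. It stands to compound 3 as compound 1 stands to compound 2: isopropyl in place of 2-(methylsulfanyl)ethyl on a saturated chain carbon bound to an amide-type nitrogen and a carbonyl carbon. The place of the change is the same in both pairs, so this is the same change, made a second time on the other core. For the measured compounds named here, the only guide to what it will do is the earlier pair, and that guide points to almost no movement, because the earlier step of a number 0.3 percentage points higher from compound 2 to compound 1 (within the scatter) lay within the scatter. The expected step is therefore a number 0.3 percentage points higher from compound 3 to compound 4 (within the scatter), which rests on that one earlier pair alone. Compound 4 is accordingly expected to give about 17.8% in this assay, with a likely range from 8% to 28%.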

Compound 4, a percentage reported as activity, at one dose (the size of the read-out at that dose, not a potency): 21.1%
Compound 4: middle estimate off by 3.3 percentage points, on the low side; the measured number falls inside the stated range.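

In this assay, putting isopropyl in place of 2-(methylsulfanyl)ethyl on the core of compound 3 gives a step of a number 3.6 percentage points higher from compound 3 to compound 4 (within the scatter). Set beside the same change on the core of compound 1, this step does not stand apart from the earlier one: the same change on two cores in this assay, a number 0.3 percentage points higher (within the scatter) from compound 2 to compound 1 and a number 3.6 percentage points higher (within the scatter) from compound 3 to compound 4, 3.3 percentage points apart, within the scatter of two such steps. The change therefore looks alike on both cores as far as these numbers can tell, but neither step stands clear of the scatter, so this is agreement between two small steps and not proof of a real effect that carries from one core to the other; two pairs at a single dose and a single time also cannot exclude a modest difference between the cores.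

At this place on the chain, the compounds shown carry only isopropyl and 2-(methylsulfanyl)ethyl, so it stays open what a longer chain, an amine or a carboxylic acid would do there, and whether any such group would give a step clear of the scatter. From the compounds shown here alone, it also stays open whether the likeness of the two steps would hold at other doses or other times after dosing.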